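This account rests on a few compounds, and the source may have more. Where it says the series, first, only, none or still open, it means among the compounds named here.

Measured so far in a functional assay on KYSE-70 cells for antiproliferative activity against KYSE-70 cell line (Homo sapiens), read by MTT assay, with a stated time of 72 h; a higher number here means a weaker inhibitor, a lower number a stronger inhibitor:
compound 1 `COc1ccc2c(C(=O)Nc3cc(F)cc(F)c3)cc(=O)[nH]c2c1` — > 20000 nM.
compound 2 `O=C(Nc1cc(F)cc(F)c1)c1cc(=O)[nH]c2cc(O)ccc12` — > 20000 nM.
compound 3 `COc1cccc2c(C(=O)Nc3cc(F)cc(F)c3)cc(=O)[nH]c12` — > 20000 nM.

For compound 1 the value > 20000 nM is a limit of the assay, not a number. For compound 2 the value > 20000 nM is likewise a limit. For compound 3 the value > 20000 nM is a limit as well. All three therefore sit at the limit of > 20000 nM in this assay, at which 3 of the 3 values shown sit.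

The change from compound 1 to compound 2 is hydrogen in place of methyl on an oxygen on an aromatic ring. The step it made in this assay is a step that the two limits leave unreadable from compound 1 to compound 2; with both ends at the limit, its size cannot be read.

Compound 3 holds the same atoms as compound 1 joined differently; how the two cores differ is not broken down here. Compound 4 `O=C(Nc1cc(F)cc(F)c1)c1cc(=O)[nH]c2c(O)cccc12` is not yet measured and arises from compound 3 by the same change, (hydrogen in place of methyl on an oxygen on an aromatic ring).

In this assay the step that the limit leaves unreadable from compound 3 to compound 4 is expected, resting on the measured pair, where the step that the two limits leave unreadable from compound 1 to compound 2 stayed at the limit on both sides. Compound 4 is estimated at 30000 nM, with a range from 10000 nM to 100000 nM, most probably reported again only as a limit.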

Compound 4, half-maximal inhibitory concentration: > 20000 nM
Compound 4 was reported as a limit; the forecaster's own chance of this, stated with the estimate: 85%; the middle value is on the limit's open side.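

In this assay compound 4 gives > 20000 nM, which is a limit and not a number. Compound 3 also stands at a limit, so no size can be read for the change from methoxy to hydroxy between compound 3 and compound 4: the limit of > 20000 nM in this assay, at which 4 of the 4 values shown sit. The compounds shown leave open how far past this limit each one truly lies.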